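The source may hold more compounds than are shown below. What is called first, only, known or untested is meant among the compounds shown, and "the series" means these compounds.

Among the compounds with values here, in a functional assay on the whole organism with Mus musculus as the target (a lower number here means that less compound is needed, a higher number that more compound is needed for the effect), compound 1 `CN1C(=O)CCC1(O)c1cccc(C(F)(F)F)c1` gives 93.8 mg/kg, the only actual number in this small set. Compound 2 `CCN1C(=O)CCC1(O)c1cccc(C(F)(F)F)c1` reads > 100 mg/kg, which is a limit. Compound 3 `CCCCN1C(=O)CCC1(O)c1cccc(C(F)(F)F)c1` reads > 200 mg/kg, which is also a limit. Lengthening the chain on the amide-type nitrogen gave an at least 1.0-fold higher number from compound 1 to compound 2 (0.02 log units; that floor lies within the scatter), then an at least 2.1-fold higher number from compound 1 to compound 3 (0.32 log units; beyond the scatter), and finally a step that the two limits leave unreadable from compound 2 to compound 3. Compound 4 `CN1C(=O)CCC1(O)c1cccc(Cl)c1` keeps the chain of compound 1 and has chloro in place of trifluoromethyl on an aromatic carbon. Within the data shown here, none of the measured steps touches that place, so they set no size for this change. No step beyond the scatter is therefore expected in this assay, and the estimated step is a 1.0-fold higher number from compound 1 to compound 4 (0.01 log units; within the scatter). For compound 4 the estimate is 95 mg/kg, with an expected range of 45 mg/kg to 200 mg/kg.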

Compound 4, dose for half-maximal effect: 158 mg/kg
For compound 4 the middle estimate is 1.7-fold (0.22 log units) below the measured one, and the stated range covers the measured number.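

In this assay, within the data shown here, this is the first reading of a change on the aromatic carbon, where the earlier compounds all carry trifluoromethyl. Replacing that group of 4 heavy atoms with chloro, a single heavy atom, gives a 1.7-fold higher number from compound 1 to compound 4 (0.23 log units; within the scatter), so the two compounds cannot be told apart here. Nothing shown accounts for the size of this step. On these data alone, whether a nitrile or a methoxy group on that same carbon would also stay within the scatter remains open. So does how chloro would read with the longer nitrogen chains of compound 2 and compound 3.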